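The source may hold more compounds than are shown below. What is called first, only, known or untested is meant among the compounds shown, and "the series" means these compounds.

Compound 1 `COc1cccc(/C=N\NC(=O)C2=C(Cl)c3ccccc3CCC2)c1` gives < 10 nM.
Compound 2 `COc1ccc(/C=N\NC(=O)C2=C(Cl)c3ccccc3CCC2)c(OC)c1` gives 14900 nM.
Compound 3 `COc1cc(/C=N\NC(=O)C2=C(Cl)c3ccccc3CCC2)cc(OC)c1OC` gives < 10 nM.

In a functional assay on IMR-32 cells (Homo sapiens) for inhibition, read by sulforhodamine B assay, with a stated time of 48 h (a lower number here means a stronger inhibitor of growth, a higher number a weaker inhibitor of growth), compound 1 stands only at a limit of the assay, namely (the limit of < 10 nM in this assay, at which 2 of the 3 values shown sit), so no number is known for it. Compound 3 likewise reaches only a limit there. Compound 2 alone gives a number, one far from that limit. Compound 4 `O=C(N/N=C\c1ccc(F)cc1)C1=C(Cl)c2ccccc2CCC1` is not yet measured; it differs from compound 1 by 4-fluorophenyl in place of 3-methoxyphenyl on a carbon with a double bond to nitrogen. Going by the values given here, no step between measured compounds is known, so the size of this change cannot be read from the data; a modest loss beyond the scatter is expected in this assay, with wide uncertainty. Compound 4 is expected at 40 nM, within 5 nM to 1500 nM. The expected step is an at least 4.0-fold higher number from compound 1 to compound 4 (0.60 log units; beyond the scatter).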

Compound 4, concentration for 50% growth inhibition: 270 nM
Compound 4: middle estimate off by 6.8-fold (0.83 log units), on the low side, within the range that was stated.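

Going by these compounds alone, putting 4-fluorophenyl in place of 3-methoxyphenyl on the carbon with a double bond to nitrogen gives the first readable step at this position in this assay: an at least 27-fold higher number from compound 1 to compound 4 (1.43 log units; beyond the scatter). This single exchange is enough to move the number clear of the limit, so the position does not tolerate every aryl group equally. Compound 1 itself gives only a limit, so the step has no known upper size: the limit of < 10 nM in this assay, at which 2 of the 4 values shown sit.

The compounds shown do not separate the departure of the methoxy group from the arrival of the fluorine. On these data alone, how an amine or a nitrile on that phenyl ring would read also remains open.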